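The compounds below may be only part of what the source reports. "The series", "measured", "known", "first", "only" and "open" are said of these compounds alone.

Measured compounds in an assay on isolated protein for inhibition of Trypsin (Homo sapiens); on this read-out higher numbers stand for weaker inhibition and lower numbers for stronger inhibition:

Compound 1 `CCOc1cc(C(Nc2ccc3c(N)nccc3c2)C(=O)NS(=O)(=O)c2cccc(CO)c2)ccc1OC(C)C` gives > 5000 nM, a limit of the assay.
Compound 2 `CCOc1cc(C(Nc2ccc3c(N)nccc3c2)C(=O)NS(=O)(=O)c2cccc(S(N)(=O)=O)c2)ccc1OC(C)C` gives > 5000 nM, a limit of the assay.
Compound 3 `CCOc1cc(C(Nc2ccc3cnccc3c2)C(=O)NS(=O)(=O)c2ccccc2S(C)(=O)=O)ccc1OC(C)C` gives > 5000 nM, a limit of the assay.

Where compound 3 stands: in this assay compound 3 is reported only as a limit, and it shares that position with the two other measured compounds, since (the limit of > 5000 nM in this assay, at which 3 of the 3 values shown sit). Among the measured compounds shown here, no measured compound has a numeric inhibition constant.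

For the measured compounds named here, the one single-site change among the measured compounds is a step that the two limits leave unreadable from compound 1 to compound 2; both ends of that step are limits, so its size cannot be read. It concerns a different part of the molecule from the change considered here and gives no usable calibration.

Compound 4 `CCOc1cc(C(Nc2ccc3cnccc3c2)C(=O)NS(=O)(=O)c2ccc(S(C)(=O)=O)cc2)ccc1OC(C)C` differs from compound 3 by 4-(methylsulfonyl)phenyl in place of 2-(methylsulfonyl)phenyl on a sulfonyl sulfur. Going by the values given here, no measured step bears on a repositioning of the methylsulfonyl group on this ring, and the only step is unreadable. Compound 3 sits at the limit in this assay, which is the sole point of reference. Compound 4 is therefore expected to show a step that the limit leaves unreadable from compound 3 to compound 4, meaning no step beyond the scatter and most likely another limit. Compound 4 is estimated at 10000 nM, within a range of 3000 nM to 50000 nM.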

Compound 4, inhibition constant: > 5000 nM
Compound 4 was reported as a limit; the forecaster's own chance of this, stated with the estimate: 85%; the middle value does not contradict the limit.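

In this assay no step can be read from compound 3 to compound 4, as both are reported only as limits: the limit of > 5000 nM in this assay, at which 4 of the 4 values shown sit.

The compounds shown leave open whether 4-(methylsulfonyl)phenyl and 2-(methylsulfonyl)phenyl differ at all on this read-out, and whether any compound in the series reaches a numeric inhibition constant.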